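The compounds below may be only part of what the source reports. "The series", "measured", "known", "first", "only" and "open" are said of these compounds alone.

In a functional assay on MGC-803 cells (Homo sapiens) for antiproliferative activity, read by MTT assay, with a stated time of 72 h (a higher number here means a weaker inhibitor, a lower number a stronger inhibitor), compound 1 `O=C(N/N=C/c1ccccn1)c1cccc(S(=O)(=O)N2CCOCC2)c1` gives 81700 nM, compound 2 `CCOc1cccc(/C=N/NC(=O)c2cccc(S(=O)(=O)N3CCOCC3)c2)c1O` gives 18000 nM and compound 3 `O=C(N/N=C/c1cc(Cl)ccc1O)c1cccc(S(=O)(=O)N2CCOCC2)c1` gives 11000 nM. Compound 3 thus stands level with compound 2 at the low end of these numbers: a 1.6-fold lower number from compound 2 to compound 3 (0.21 log units; within the scatter) lies within the scatter, while a 4.5-fold lower number from compound 1 to compound 2 (0.66 log units; beyond the scatter) and a 7.4-fold lower number from compound 1 to compound 3 (0.87 log units; beyond the scatter) lie beyond it. Compound 4 `O=C(N/N=C/c1cc(Br)cc(Br)c1O)c1cccc(S(=O)(=O)N2CCOCC2)c1` brings one change to compound 3: 3,5-dibromo-2-hydroxyphenyl in place of 5-chloro-2-hydroxyphenyl on a carbon with a double bond to nitrogen. Among the compounds with values here, the closest precedent is the swap between two hydroxyphenyl groups, which stayed within the scatter, whereas the larger steps both leave pyridin-2-yl, and no measured compound carries bromine. In this assay the expected step is a 1.6-fold lower number from compound 3 to compound 4 (0.20 log units; within the scatter), leaning slightly lower but not beyond the scatter. Compound 4 is estimated at 7000 nM, within an expected range of 2500 nM to 20000 nM.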

Compound 4, half-maximal inhibitory concentration: 17800 nM
Estimate against measurement, compound 4: 2.5-fold (0.41 log units) below, within the range that was stated.
By their numbers in this assay, from the lowest: compounds 3, 4 and 2 (each within the scatter of the next); then compound 1.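

In this assay, placing 3,5-dibromo-2-hydroxyphenyl on this carbon with a double bond to nitrogen stays within the scatter of both other hydroxyphenyl groups (a 1.6-fold higher number from compound 3 to compound 4 (0.21 log units; within the scatter); a 1.0-fold lower number from compound 2 to compound 4 (0.00 log units; within the scatter)). All three hydroxyphenyl compounds therefore stand level, with two bromine atoms tolerated here, and the separation beyond the scatter again lies only with pyridin-2-yl (a 4.6-fold lower number from compound 1 to compound 4 (0.66 log units; beyond the scatter)). No supporting measurement is available to explain this. The compounds shown leave open whether a plain phenyl group, lacking the hydroxyl, would stay level with them. They also leave open how a dimethylamino group on that ring would fare.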